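Removing a Pyridyl Group: Expected Effect on Solubility

The compounds below may be only part of what the source reports. "The series", "measured", "known", "first", "only" and "open" are said of these compounds alone.

Measured compounds:
Compound 1, `Cc1c(COc2cccc(OCC3CCOCC3)c2)[nH]c2ccc(-c3cccnc3)cc2c1=O`, gives < 1000 nM in a physicochemical assay for solubility, at pH 6.8; on this read-out lower numbers stand for lower solubility and higher numbers for higher solubility.
Compound 2, `Cc1c(COc2cc(OCC3CCOCC3)ccn2)[nH]c2ccccc2c1=O`, gives 36000 nM.
Compound 3, `Cc1c(COc2cncc(OCCC(C)(C)O)c2)[nH]c2ccccc2c1=O`, gives >= 100000 nM.

For compound 1 the reading is a limit of the method, not a number, as noted in the limit of < 1000 nM in this assay, at which 1 of the 3 values shown sits. For compound 3 the reading is likewise a limit, noted in the limit of >= 100000 nM in this assay, at which 1 of the 3 values shown sits. Compound 2 is the only one of the three with a plain number, and it sits between the two limits. Compound 1 therefore stands at the lower end of what is shown, while compounds 2 and 3 lie well toward the upper end.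

Compound 4, `Cc1c(COc2cccc(OCC3CCOCC3)c2)[nH]c2ccccc2c1=O`, has not yet been measured. It differs from compound 1 in one place: hydrogen in place of pyridin-3-yl on an aromatic carbon. Going by the values given here, no measured pair shows this exact change on its own, so its size cannot be read from the data. Compounds 2 and 3 both carry a hydrogen at the same place and show higher readings than compound 1, but they also differ elsewhere, so they only hint at the direction.

Compound 4 is expected to show a step of an at least 5.0-fold higher number from compound 1 to compound 4 (0.69 log units; beyond the scatter) in this assay, toward higher solubility. Compound 4 is estimated at 5000 nM, within a range from 800 nM to 40000 nM.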

Compound 4, solubility: 5000 nM
Compound 4: middle estimate and measured number agree at the digits printed; measured number inside the range.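

In this assay, going by these compounds alone, this is the first pair that differs in one place only, so the swap of pyridin-3-yl for hydrogen on this aromatic carbon can now be read without other changes in the way: the reading shows an at least 5.0-fold higher number from compound 1 to compound 4 (0.69 log units; beyond the scatter). The earlier compounds shown here carrying hydrogen here also differed elsewhere and gave only a hint of the direction, whereas this step ties the rise to this one place. The reading of compound 1 is a limit and not a number, so the step has a known minimum but no known full size: the limit of < 1000 nM in this assay, at which 1 of the 4 values shown sits.

With everything else in the structure unchanged, compound 4 gives 5000 nM, a plain number that can serve as a firm reference for further changes at this place.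

Only pyridin-3-yl and hydrogen are shown on this carbon, so it remains open where a plain phenyl ring, pyridin-4-yl or a small methyl group would fall in this assay. Going by these compounds, it also remains open whether the same swap would give a step of similar size in a compound with a different side chain.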